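Swapping the Amino Group for Chlorine on a Purine Core

The source may hold more compounds than are shown below. What is called first, only, known or untested is meant among the compounds shown, and "the series" means these compounds.

Measured compounds:
- compound 1 `Nc1nc(Cl)c2ncn(Cc3ccccc3CCl)c2n1`: 79400 nM
- compound 2 `Nc1nc(Cl)c2ncn(Cc3ccc(CCl)cc3)c2n1`: > 100000 nM
- compound 3 `ClCc1ccccc1Cn1cnc2nc(Cl)nc(Cl)c21`: 28800 nM

All three were tested in a functional assay on OVCAR-5 cells (Homo sapiens) for cytotoxicity, read by sulforhodamine B assay, with a stated time of 48 h; on this read-out higher numbers stand for lower toxicity in this test and lower numbers for higher toxicity in this test. Compound 1 gives 79400 nM in this assay, the highest of the two numbers reported. The nearest number belongs to compound 3, which gives 28800 nM, a gap from compound 1 that lies beyond the usual scatter, so compound 3 is the more toxic of the two in this test. For compound 2 only a limit is reported, > 100000 nM, not a number; one of the three values sits at this limit, (the limit of > 100000 nM in this assay, at which 1 of the 3 values shown sits).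

The compound still to be measured is compound 4 `ClCc1ccccc1Cn1cnc2c(Cl)nc(Cl)nc21`. It differs from compound 1 in one place: chloro in place of amino on an aromatic carbon. Both compounds keep the same benzyl substituent carrying the chloromethyl chain, and the same fused two-ring core. For the measured compounds named here, no measured pair here shares exactly this change, so there is no directly matching step to lean on. Compound 3 carries two chloro groups and no amino group and gives the lower number, but it is not a single-change partner of compound 4.

For compound 4 the expected step in this assay is a 2.0-fold lower number from compound 1 to compound 4 (0.30 log units; within the scatter), a modest move toward greater toxicity. The estimated value for compound 4 is 40000 nM, with a range from 15000 nM to 100000 nM.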

Compound 4, concentration lethal to 50% of the cells: 5620 nM
Estimate against measurement, compound 4: 7.1-fold (0.85 log units) above; the measured number lies below the stated range.
By their numbers in this assay, from the lowest: compound 4; then compound 3; then compound 1. At a limit, above all of these: compound 2.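

In this assay, putting chloro in place of amino on this aromatic carbon, which sits between two ring nitrogen atoms, gives a 14-fold lower number from compound 1 to compound 4 (1.15 log units; beyond the scatter). For the compounds shown here, the earlier compounds offered no pair differing in only one place, so this is the first direct reading of what a change at this position can do, and it shows that this single swap is enough to move the number well beyond the scatter. A lower number stands for higher toxicity in this test, so compound 4, at 5620 nM, is far more toxic here than compound 1, even though only one heavy atom has been exchanged.

The compounds shown give only this one swap at this position, so it remains open how a methoxy group or a methylamino group on the same carbon would compare with amino and chloro. The swap removes a hydrogen-bond donor and a hydrogen-bond acceptor, but nothing measured here tells why the number falls so far.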